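Ether-linked arylethyl variants: microsomal stability notes

The source may hold more compounds than are shown below. What is called first, only, known or untested is meant among the compounds shown, and "the series" means these compounds.

Measured compounds:
compound 1, `Cc1nc(C)c([C@H](OC(C)(C)C)C(=O)O)c(N2CCC(C)(C)CC2)c1-c1ccc(SCCc2ccc(F)cc2)cc1`, in an ADME assay on microsomes from liver (Rattus norvegicus) for metabolic stability, read by LC-MS, tested at 0.5 uM; a higher number here means that the compound lasts longer, a lower number that the compound disappears faster: > 2 h, which is a limit of the assay and not a number.
compound 2, `Cc1nc(C)c([C@H](OC(C)(C)C)C(=O)O)c(N2CCC(C)(C)CC2)c1-c1ccc(OCCc2ccccn2)cc1`, in this assay: 1.02 h.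
compound 3, `Cc1nc(C)c([C@H](OC(C)(C)C)C(=O)O)c(N2CCC(C)(C)CC2)c1-c1ccc(OCCc2cccnc2)cc1`, in this assay: 0.783 h.

Of the two numerical values in this assay, compound 3 and compound 2 sit close together: a 1.3-fold lower number from compound 2 to compound 3 (0.11 log units; within the scatter). Against compound 1, whose value is only a limit (the limit of > 2 h in this assay, at which 1 of the 3 values shown sits), the step of an at least 2.5-fold lower number from compound 1 to compound 3 (0.40 log units; beyond the scatter), while an at least 1.9-fold lower number from compound 1 to compound 2 (0.29 log units; that floor lies within the scatter).

Compound 4, `Cc1nc(C)c(CCOc2ccc(-c3c(C)nc(C)c([C@H](OC(C)(C)C)C(=O)O)c3N3CCC(C)(C)CC3)cc2)s1`, differs from compound 3 in one place: 2,4-dimethyl-1,3-thiazol-5-yl in place of pyridin-3-yl on a saturated chain carbon, two bonds along the chain from an oxygen on an aromatic ring. Going by the values given here, none of the measured steps carries this exchange. Among the compounds with values here, the steps from compound 1 swap the whole sulfanyl-linked arylethyl group for an oxygen-linked pyridylethyl group and so say little about a change of the terminal ring alone; the one step that does change the terminal ring alone, a 1.3-fold lower number from compound 2 to compound 3 (0.11 log units; within the scatter), stays within the scatter. On that basis the expected step of a 1.0-fold higher number from compound 3 to compound 4 (0.01 log units; within the scatter) is none beyond the scatter. The half-life of compound 4 in this assay is estimated at 0.8 h, with a range from 0.4 h to 1.6 h.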

Compound 4, half-life: > 2 h
Compound 4 was reported as a limit; the forecaster's own chance of this, stated with the estimate: 10%; at least 2.5-fold (0.39 log units) between middle value and limit.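

The terminal ring at this place, on a saturated chain carbon two bonds along the chain from an oxygen on an aromatic ring, can shift the half-life in this assay with the ethoxy link held: 2,4-dimethyl-1,3-thiazol-5-yl gives a step beyond the scatter against pyridin-3-yl (an at least 2.5-fold higher number from compound 3 to compound 4 (0.40 log units; beyond the scatter)), while the exchange between the two pyridines stayed within it (a 1.3-fold lower number from compound 2 to compound 3 (0.11 log units; within the scatter)). Against pyridin-2-yl the floor of the step lies within the scatter (an at least 1.9-fold higher number from compound 2 to compound 4 (0.29 log units; that floor lies within the scatter)), so only the comparison with compound 3 is firm, and the step involving compound 1 cannot be read. Compound 4 gives a limit of the assay and not a number: the limit of > 2 h in this assay, at which 2 of the 4 values shown sit.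

The compounds shown leave open whether the thiazole ring or its two methyl groups account for the step, a question that a plain 1,3-thiazol-5-yl at this place would address. Also open is what number lies behind the limit of compound 4.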